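This account rests on a few compounds, and the source may have more. Where it says the series, first, only, none or still open, it means among the compounds named here.

Measured so far:
compound 1 `Cc1ccc(-c2nc3ccc(Br)cn3c2/C=N/OCc2cn(Cc3ccc([N+](=O)[O-])cc3)nn2)cc1` — 20 mg/kg
compound 2 `COc1ccc(Cn2cc(CO/N=C/c3c(-c4ccc(C)cc4)nc4c(C)cccn34)nn2)cc1` — 40 mg/kg
compound 3 `COc1ccc(Cn2cc(CO/N=C/c3c(-c4ccc(F)cc4)nc4c(C)cccn34)nn2)cc1` — 40 mg/kg

All three were tested in a functional assay on the whole organism (strain NMRI) with Mus musculus as the target, with a stated time of 0.5 h; a higher number here means that more compound is needed for the effect, a lower number that less compound is needed. Compound 2 and compound 3 share one core and differ in a single place: fluoro in place of methyl on an aromatic carbon. That change gave no change at the digits printed from compound 2 to compound 3 (within the scatter). Compound 1 is built on another core, and the difference between the two cores is not broken down here. The number for compound 1 lies within the scatter of those for compound 2 and compound 3, so no order among the three can be read from these values.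

Compound 4, `O=[N+]([O-])c1ccc(Cn2cc(CO/N=C/c3c(-c4ccc(F)cc4)nc4ccc(Br)cn34)nn2)cc1`, is not yet measured. For the measured compounds named here, it differs from compound 1 by fluoro in place of methyl on an aromatic carbon, which is the same change as the one between compound 2 and compound 3, at the same kind of place. The expected step is no change at the digits printed from compound 1 to compound 4 (within the scatter). That expectation rests on no change at the digits printed from compound 2 to compound 3 (within the scatter), seen in one pair only, so it is tentative. Compound 4 is therefore estimated to give about 20 mg/kg in this assay, expected between 10 mg/kg and 40 mg/kg.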

Compound 4, minimum effective dose: 40 mg/kg
Estimate against measurement, compound 4: 2.0-fold (0.30 log units) below; the range from low to high includes it.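

In this assay, the change from 4-methylphenyl to 4-fluorophenyl on the core of compound 1 gave a 2.0-fold higher number from compound 1 to compound 4 (0.30 log units; within the scatter). Set beside the earlier pair on the other core, the change looks the same on both cores, as far as this read-out can tell: the same change on two cores in this assay, no change at the digits printed (within the scatter) from compound 2 to compound 3 and a 2.0-fold higher number (0.30 log units; within the scatter) from compound 1 to compound 4, 2.0-fold (0.30 log units) apart, within the scatter of two such steps

For the compounds shown here, this supports carrying the change between these two cores without expecting a clear shift in dose, but it rests on only two pairs, and a small real effect, or a small difference between the cores, could stay hidden in the scatter. It also does not show that the methyl and fluoro groups are interchangeable in general, or in any other kind of test.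

The compounds shown leave open whether a different group at this place, such as chloro, an amine or a carboxylic acid, would give a clear step. They also leave open whether a third core would respond to the change in the same way.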